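The source may hold more compounds than are shown below. What is called first, only, known or untested is meant among the compounds shown, and "the series" means these compounds.

Measured so far in an ADME assay; a lower number here means that the compound disappears faster, a higher number that the compound lasts longer:
Compound 1 `COc1ccc(C[S+]([O-])c2ncccc2C(=O)Nc2ccncc2)c(OC)c1C`: 11.6 h
Compound 2 `CCOc1cc(OC)ccc1C[S+]([O-])c1ncccc1C(=O)Nc1ccncc1`: 0.71 h

Compound 2, at 0.71 h, has the lower of the two numbers, and its gap to compound 1 lies well beyond the usual scatter. The next molecule, compound 3 `COc1ccc(C[S+]([O-])c2ncccc2C(=O)Nc2ccncc2)c(OC)c1`, comes from compound 2 by one small edit: hydrogen in place of methyl on a saturated chain carbon bound to an oxygen on an aromatic ring. That edit places hydrogen in place of methyl on a saturated chain carbon bound to an oxygen on an aromatic ring, turning ethoxy into methoxy. Going by the values given here, no two measured compounds show this edit, so any expectation remains loose. A modest rise in this assay seems likely, roughly the size of the scatter, leaving compound 3 much closer to compound 2 than to compound 1. The expected change is a 1.7-fold higher number from compound 2 to compound 3 (0.23 log units; within the scatter). For compound 3 the estimated value is 1.2 h, with an expected range of 0.4 h to 5 h.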

Compound 3, half-life: 0.84 h
For compound 3 the middle estimate is 1.4-fold (0.15 log units) above the measured one; the measured number falls inside the stated range.
By their numbers in this assay, from the lowest: compounds 2 and 3 (each within the scatter of the next); then compound 1.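

In this assay the edit from ethoxy to methoxy gives a 1.2-fold higher number from compound 2 to compound 3 (0.07 log units; within the scatter), so the length of this chain on the oxygen does not separate the two compounds here. A different edit, hydrogen in place of methyl on an aromatic carbon, gives a 14-fold lower number from compound 1 to compound 3 (1.14 log units; beyond the scatter) in this assay, which shows that this single methyl goes with a large gap while the ethoxy-to-methoxy edit does not. No measurement at hand explains why either edit has the effect it does.

As far as these compounds go, it remains open whether a longer chain, such as propoxy, would behave like ethoxy and methoxy, and whether the ethoxy-to-methoxy edit would also be this small with the aromatic methyl present. Also open, from the compounds shown here alone, is whether chlorine or trifluoromethyl in place of that methyl would keep a number like that of compound 1 at 11.6 h in this assay.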